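The source may report more compounds than this note shows. Statements on the series, on what has been measured and on what is new or still open speak of the compounds shown alone.

Compound 1, `Cc1ccccc1-c1cccc(COc2ccc([C@H](CC(=O)O)c3nccn3C)cc2)c1`, stands at the lower of the two numbers recorded so far. In an assay on CHO cells for agonist activity at Free fatty acid receptor 1 (Homo sapiens), read by luminescence, with a stated time of 20 s, in the presence of a further agent that is not named here (on this read-out higher numbers stand for an effect only at larger amounts of compound and lower numbers for an effect already at smaller amounts), compound 1 gives 43 nM. Among the measured compounds shown here, compound 2, `Cc1cc(Cl)ccc1-c1cccc(COc2ccc([C@H](CC(=O)O)c3nccn3C)cc2)c1C`, differs from compound 1 in more than one place, and in this assay compound 2 gives 240 nM, a higher number; as the two differ at more than one position, no single step links them. Compound 3, `Cc1cccc(C)c1-c1cccc(COc2ccc([C@H](CC(=O)O)c3nccn3C)cc2)c1`, has not yet been measured. It departs from compound 1 in one place: methyl in place of hydrogen on an aromatic carbon. Cut one bond further out, the change reads 2-methylphenyl to 2,6-dimethylphenyl, the entering methyl sitting ortho to a large group and meta to a methyl group. For the measured compounds named here, no measured pair shows this kind of step, so the expectation rests on the standing of compound 1 alone. In this assay the step is expected to be small, with no clear direction, most likely within the scatter. Compound 3 is expected to give 60 nM, with a range from 20 nM to 200 nM. The step of a 1.4-fold higher number from compound 1 to compound 3 (0.14 log units; within the scatter) is thereby expected to be modest.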

Compound 3, half-maximal effective concentration: 58 nM
For compound 3 the middle estimate is 1.0-fold (0.01 log units) above the measured one; the measured number falls inside the stated range.
By their numbers in this assay, from the lowest: compounds 1 and 3 (each within the scatter of the next); then compound 2.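

In this assay, among the compounds shown here, replacing 2-methylphenyl with 2,6-dimethylphenyl gives a 1.3-fold higher number from compound 1 to compound 3 (0.13 log units; within the scatter), the first step that isolates a single place, so compound 1 and compound 3 cannot be told apart on this read-out. A second methyl on the aromatic carbon, ortho to a large group and meta to a methyl group, is therefore tolerated in this one pair, although a single pair sets no general rule. No measurement at hand accounts for this outcome.

What a group other than methyl would do at this position stays open, as a chlorine, a methoxy group and an amine there are not among the compounds shown. Compound 2 differs from both compound 1 and compound 3 in more than one place, so the separate contributions of its chlorine and its methyl on the central ring cannot be read from these compounds.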